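The compounds below may be only part of what the source reports. "The series", "measured", "known", "first", "only" and "open" are said of these compounds alone.

Working notes on the series. The starting point is compound 1 `CCC(/C=C(\COC(=O)c1ccccc1)C(=O)c1ccc(OC)cc1)CC`. In a functional assay on A549 cells (Homo sapiens) for inhibition, read by XTT assay, with a stated time of 48 h (on this read-out higher numbers stand for weaker inhibition and lower numbers for stronger inhibition), compound 1 reports only a limit, > 100000 nM. Compound 2 `COc1ccc(C(=O)/C(=C/C2CCCCC2)COC(=O)c2ccccc2)cc1` differs from compound 1 by cyclohexyl in place of pentan-3-yl on a double-bonded chain carbon bound to a double-bonded chain carbon. In this assay compound 2 gives 36000 nM, a step of an at least 2.7-fold lower number from compound 1 to compound 2 (0.44 log units; beyond the scatter). Compound 3 `CCC(/C=C(\CCOC(C)=O)C(=O)c1ccc(OC)cc1)CC` differs from compound 1 by acetoxymethyl in place of benzoyloxy on a saturated chain carbon bound to a double-bonded chain carbon. In this assay compound 3 likewise reports only a limit, > 100000 nM. The step that the two limits leave unreadable from compound 1 to compound 3 cannot be sized, since both ends sit at the limit of > 100000 nM in this assay, at which 2 of the 3 values shown sit. Compound 4 `COc1ccc(C(=O)/C(=C/C2CCCCC2)CCOC(C)=O)cc1`, not yet measured, stands to compound 3 as compound 2 stands to compound 1: cyclohexyl in place of pentan-3-yl on a double-bonded chain carbon bound to a double-bonded chain carbon, the same change at the same place. Compound 4 is expected to show a step of about an at least 1.6-fold lower number from compound 3 to compound 4 (0.22 log units; that floor lies within the scatter), resting on an at least 2.7-fold lower number from compound 1 to compound 2 (0.44 log units; beyond the scatter). The estimate for compound 4 in this assay is 60000 nM, with a range from 20000 nM to 200000 nM.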

Compound 4, half-maximal inhibitory concentration: > 100000 nM
Compound 4 ended at the assay's limit (the forecaster's own chance of this, stated with the estimate: 45%); middle value at least 1.6-fold (0.22 log units) from the limit.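

In this assay compound 4 reports only a limit, > 100000 nM. The cyclohexyl change that gave a readable step on the core of compound 1 can be neither confirmed nor ruled out on the core of compound 3, and the steps between limits cannot be read, because both ends sit at one value: the limit of > 100000 nM in this assay, at which 3 of the 4 values shown sit. What can be read is an at least 2.7-fold higher number from compound 2 to compound 4 (0.44 log units; beyond the scatter), for acetoxymethyl in place of benzoyloxy, so a measured cyclohexyl effect rests on one core only.

The compounds shown leave open whether any group on the core of compound 3 gives a readable number. A phenyl, an amine or a carboxylic acid in place of cyclohexyl remains an open case.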